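The compounds below may be only part of what the source reports. "The series", "measured", "known", "first", "only" and "open" are said of these compounds alone.

Compound 1 `FC(F)(F)c1ccc(COc2cccc(Nc3ncnc4cc5c(cc34)OCCOCCOCCOCCO5)c2)cc1` and compound 2 `O=[N+]([O-])c1ccc(COc2cccc(Nc3ncnc4cc5c(cc34)OCCOCCOCCOCCO5)c2)cc1` share one core and differ only in that (nitro in place of trifluoromethyl on an aromatic carbon). In a functional assay on MCF7 cells (Homo sapiens) for antiproliferative activity, read by MTT assay, with a stated time of 72 h (a higher number here means a weaker inhibitor, a lower number a stronger inhibitor), compound 1 gives 8480 nM. Compound 2 gives 6410 nM in this assay, a step of a 1.3-fold lower number from compound 1 to compound 2 (0.12 log units; within the scatter). Compound 3 `FC(F)(F)c1ccc(COc2cccc(Nc3ncnc4cc5c(cc34)OCCOCCO5)c2)cc1` carries a different core; the difference between the two cores is not broken down here. In this assay compound 3 reaches only a limit, > 100000 nM. Compound 4 `O=[N+]([O-])c1ccc(COc2cccc(Nc3ncnc4cc5c(cc34)OCCOCCO5)c2)cc1` stands to compound 3 as compound 2 does to compound 1: nitro in place of trifluoromethyl on an aromatic carbon, the same change at the same place. The step is expected to be a step that the limit leaves unreadable from compound 3 to compound 4, an expectation resting on compound 3 standing at the limit of > 100000 nM in this assay, at which 1 of the 3 values shown sits, and on the small movement seen in a 1.3-fold lower number from compound 1 to compound 2 (0.12 log units; within the scatter). Compound 4 is therefore estimated at 130000 nM, between 40000 nM and 400000 nM, and will most likely again be reported only as a limit.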

Compound 4, half-maximal inhibitory concentration: 42400 nM
Estimate against measurement, compound 4: 3.1-fold (0.49 log units) above; the range from low to high includes it.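

In this assay, nitro in place of trifluoromethyl on the core of compound 3 gives an at least 2.3-fold lower number from compound 3 to compound 4 (0.37 log units; beyond the scatter), so the change is readable on this core even though compound 3 is known only as a limit. On the core of compound 1, the same change gives a 1.3-fold lower number from compound 1 to compound 2 (0.12 log units; within the scatter). This does not show that the change has a larger effect on one core than on the other: the same change on two cores in this assay, a 1.3-fold lower number (0.12 log units; within the scatter) from compound 1 to compound 2 and an at least 2.3-fold lower number (0.37 log units; beyond the scatter) from compound 3 to compound 4; the limit leaves it open whether they differ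

The compounds shown leave open how far the number would move with a nitrile, an amine or a carboxylic acid on the same aromatic carbon. They also leave open whether any such group would behave alike on both cores.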